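Chloro for fluoro in an inactive pair

This account rests on a few compounds, and the source may have more. Where it says the series, first, only, none or still open, it means among the compounds named here.

Measured so far:
compound 1, `CC(O)(CS(=O)(=O)c1ccc(Cl)cc1)c1nc(-c2ccc(Cl)cc2)no1`, in a functional assay on DU-145 cells (Homo sapiens) for cytotoxicity, read by MTT assay; a lower number here means a stronger inhibitor, a higher number a weaker inhibitor: > 100000 nM
compound 2, `CC(O)(CS(=O)(=O)c1ccc(F)cc1)c1nc(-c2ccccc2)no1`, in this assay: > 100000 nM

Compound 2 gives only a limit in this assay, not a number. The same holds for compound 1, so both values shown sit at the limit (the limit of > 100000 nM in this assay, at which 2 of the 2 values shown sit). Compound 3 `CC(O)(CS(=O)(=O)c1ccc(Cl)cc1)c1nc(-c2ccccc2)no1` differs from compound 2 by chloro in place of fluoro on an aromatic carbon. Among the compounds with values here, no step between measured compounds is available. With both shown values at the limit, no step beyond the scatter is expected in this assay. For compound 3 the expected value is 100000 nM, between 50000 nM and 200000 nM. This estimate means a step of a number no higher from compound 2 to compound 3 (the limit leaves the size open), expected to stay at the limit.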

Compound 3, half-maximal inhibitory concentration: > 100000 nM
Compound 3 was reported as a limit; the forecaster's own chance of this, stated with the estimate: 85%; the middle value sits exactly at the limit.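

Compound 3 also gives only a limit, > 100000 nM, in this assay. No step from compound 1 or compound 2 to compound 3 can be read: the limit of > 100000 nM in this assay, at which 3 of the 3 values shown sit.

Left open is what chloro in place of fluoro, or hydrogen in place of chloro, does to a compound with a measurable value in this assay.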